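Swapping one group on a carbonyl carbon of compound 1

This account rests on a few compounds, and the source may have more. Where it says the series, first, only, none or still open, it means among the compounds named here.

Among the compounds with values here, in a functional assay on DLD-1 cells (Homo sapiens) for inhibition, read by luminescence, with a stated time of 3 days (a lower number here means a stronger inhibitor of growth, a higher number a weaker inhibitor of growth), compound 1 `CC(C)C1=C(C(=O)N2[C@H](C)CC[C@H]2C(=O)N2CCN(C)CC2)SC2=N[C@@](C)(c3ccc(Cl)cc3)[C@@H](c3ccc(Cl)cc3)N21` gives 9000 nM, the highest of the three numbers measured so far. Compound 2 `CC[C@@H]1CC[C@@H](C(=O)N2CCN(C)CC2)N1C(=O)C1=C(C(C)C)N2C(=N[C@@](C)(c3ccc(Cl)cc3)[C@H]2c2ccc(Cl)cc2)S1` gives 4000 nM and compound 3 `CC[C@@H]1CC[C@@H](C(=O)N2CCOCC2)N1C(=O)C1=C(C(C)C)N2C(=N[C@@](C)(c3ccc(Cl)cc3)[C@H]2c2ccc(Cl)cc2)S1` gives 4200 nM. Compound 4 `CC(=O)N1CCN(C(=O)[C@@H]2CC[C@@H](C)N2C(=O)C2=C(C(C)C)N3C(=N[C@@](C)(c4ccc(Cl)cc4)[C@H]3c3ccc(Cl)cc3)S2)C[C@H]1C` keeps the core of compound 1 and differs in one group: a group of 10 heavy atoms (7 carbon, 2 nitrogen, 1 oxygen; one six-membered non-aromatic ring with 2 hetero atoms) in place of a group of 7 heavy atoms (5 carbon, 2 nitrogen; one six-membered non-aromatic ring with 2 hetero atoms), on a carbonyl carbon.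

The measured step closest to this change is the swap of 4-methylpiperazin-1-yl for morpholin-4-yl on a carbonyl carbon, which gave a 1.1-fold higher number from compound 2 to compound 3 (0.02 log units; within the scatter). The other step, a 2.3-fold lower number from compound 1 to compound 2 (0.35 log units; beyond the scatter), came from methyl in place of hydrogen on a saturated chain carbon, a different place in the molecule, so it bears little on this change. Within the data shown here, only one swap at the carbonyl carbon has been measured, and its entering group is not the one in compound 4, so the range stays wide. In this assay the expected change is no more than scatter, an estimated 1.1-fold lower number from compound 1 to compound 4 (0.05 log units; within the scatter). For compound 4 the estimate is 8000 nM, with an expected range of 3500 nM to 18000 nM.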

Compound 4, concentration for 50% growth inhibition: 11000 nM
Compound 4: middle estimate off by 1.4-fold (0.14 log units), on the low side; the range from low to high includes it.
By their numbers in this assay, from the lowest: compounds 2 and 3 (each within the scatter of the next); then compounds 1 and 4 (each within the scatter of the next).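

In this assay, putting the group of 10 heavy atoms, with its double bond outside aromatic rings and its defined stereocentre, in place of 4-methylpiperazin-1-yl on this carbonyl carbon gives a 1.2-fold higher number from compound 1 to compound 4 (0.09 log units; within the scatter). The earlier swap at this carbon, a 1.1-fold higher number from compound 2 to compound 3 (0.02 log units; within the scatter), also stayed within the scatter, so two different entering groups on two different parent compounds now leave the number unchanged within the scatter, and this larger group is no exception. No measurement shown here bears on why the number holds at this position.

Going by these compounds, it remains open whether a group of another kind on this carbonyl carbon, such as a carboxylic acid, a simple dimethylamino group or a longer chain, would move the number beyond the scatter. On these data alone, the opposite configuration at the stereocentre of the entering group in compound 4 also remains open.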